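From methyl ester to propargyl amide on a shared core

The source may hold more compounds than are shown below. What is called first, only, known or untested is meant among the compounds shown, and "the series" means these compounds.

Compound 1 `COC(=O)c1sc(-c2ccc(Cl)cc2)nc1C(Br)Br` gives 222000 nM in an ADME assay on BHK15 cells (Mesocricetus auratus) for inhibition, read by XTT assay, with a stated time of 36 h (on this read-out lower numbers stand for stronger inhibition of growth and higher numbers for weaker inhibition of growth), the highest of the three numbers measured. Its companions are compound 2 `NC(=O)c1sc(-c2ccc(Cl)cc2)nc1C(Br)Br` with 99700 nM and compound 3 `C=CCNC(=O)c1sc(-c2ccc(Cl)cc2)nc1C(Br)Br` with 40800 nM. Compound 4 `C#CCNC(=O)c1sc(-c2ccc(Cl)cc2)nc1C(Br)Br` differs from compound 1 by propargylamino in place of methoxy on a carbonyl carbon. Going by the values given here, two measured steps bear on this change: a 2.2-fold lower number from compound 1 to compound 2 (0.35 log units; beyond the scatter), and a 5.4-fold lower number from compound 1 to compound 3 (0.74 log units; beyond the scatter); a further step, a 2.4-fold lower number from compound 2 to compound 3 (0.39 log units; beyond the scatter), shows that a three-carbon chain on the amide-type nitrogen adds to the gain. A propargylamino group is therefore expected to bring a modest lowering of the same order as the allylamino group did. For compound 4 the estimate is 45000 nM, within 20000 nM to 100000 nM, which is expected to mean a 4.9-fold lower number from compound 1 to compound 4 (0.69 log units; beyond the scatter).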

Compound 4, concentration for 50% growth inhibition: 23900 nM
Compound 4: the middle estimate sits 1.9-fold (0.27 log units) above what was measured; the measured number falls inside the stated range.
By their numbers in this assay, from the lowest: compounds 4 and 3 (each within the scatter of the next); then compound 2; then compound 1.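

Propargylamino in place of methoxy on the carbonyl carbon brings a 9.3-fold lower number from compound 1 to compound 4 (0.97 log units; beyond the scatter) and is the largest step seen so far at this position, while propargyl in place of the amide hydrogen brings a 4.2-fold lower number from compound 2 to compound 4 (0.62 log units; beyond the scatter) on the same shared core. Ethynyl in place of vinyl brings a 1.7-fold lower number from compound 3 to compound 4 (0.23 log units; within the scatter) and so the triple bond does not set compound 4 apart from compound 3 on this read-out. No measurement at hand explains these steps. From the compounds shown here alone, whether a saturated propylamino group would stand level with these two amides, and whether a longer chain or a dimethylamino group on the carbonyl carbon would give a lower number still, remains open.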